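Maximal response series: from compound 2 to compound 4

The compounds below may be only part of what the source reports. "The series", "measured", "known", "first", "only" and "open" are said of these compounds alone.

Measured compounds:
compound 1 `C=CCn1c(=S)n(C2OC(COCc3ccccc3)[C@H]3OC(C)(C)O[C@@H]23)c2nc(N)nc(O)c21` gives 0%
compound 2 `CN(C)CCCn1c(=O)n(C2OC(CO)[C@@H](O)[C@H]2O)c2nc(N)nc(O)c21` gives 63%
compound 3 `C=CCn1c(=O)n(C2C[C@H](O)C(CO)O2)c2nc(N)nc(O)c21` gives 131%

In a functional assay on the whole organism with Mus musculus as the target (on this read-out higher numbers stand for larger maximal responses and lower numbers for smaller maximal responses), compound 2 holds the second highest of the three numbers. Its nearest neighbour is compound 1, lower by a gap beyond the scatter; compound 3 stands furthest from it, higher by a gap also beyond the scatter. Compound 4 `NC(=O)Cn1c(=O)n(C2OC(CO)[C@@H](O)[C@H]2O)c2nc(N)nc(O)c21` differs from compound 2 in one place: carbamoyl in place of 2-(dimethylamino)ethyl on a saturated chain carbon bound to an aromatic nitrogen. Going by the values given here, no single-change step between two measured compounds is available to calibrate this change, so the expectation rests on compound 2 alone. The step of a number 8 percentage points lower from compound 2 to compound 4 (within the scatter) is expected to be small, at most a slight decrease, and may well lie within the scatter. Compound 4 is estimated at 55% in this assay, with a range from 15% to 110%.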

Compound 4, largest response reached (reported as maximal response), in percent of the reference or control that the assay uses: 72%
Beside the measured number, compound 4's estimate is 17 percentage points below it, within the range that was stated.
By their numbers in this assay, from the lowest: compound 1; then compounds 2 and 4 (each within the scatter of the next); then compound 3.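

In this assay, going by these compounds alone, carbamoyl in place of 2-(dimethylamino)ethyl on a saturated chain carbon bound to an aromatic nitrogen gives a number 9 percentage points higher from compound 2 to compound 4 (within the scatter), the first single-place comparison. At this place, the read-out therefore does not separate 3-(dimethylamino)propyl from carbamoylmethyl, although the two differ in size and in hydrogen-bond donors. No measurement bearing on the reason for this result is available. Still open, from the compounds shown here alone, is whether a carboxylic acid or a longer chain ending in a primary amine at the same place would also stay within the scatter of compound 2.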